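Heteroaryl exchange on the ring amine nitrogen: agonist efficacy

A few compounds are considered here, and "the series" means these few. Any claim that something is new, unique, unknown or untested is made for them only; others in the source may bear on it.

Measured so far:
compound 1 `CC(C)(C)OC(=O)N1CCC(CCCNc2ccc3c(c2)CCS3(=O)=O)CC1` — 83%
compound 2 `COc1cnc(N2CCC(CCCNc3ccc4c(c3)OCC4=O)CC2)nc1` — 106%

In a functional assay on CHO-K1 cells for agonist activity at Glucose-dependent insulinotropic receptor (Mus musculus), read by HTRF and cAMP accumulation, with a stated time of 30 min (a lower number here means a smaller maximal response, a higher number a larger maximal response), compound 2 gives 106%, the higher of the two values in hand, a maximal response at the level of the reference. Compound 1 gives 83% in this assay, a number lower by more than the usual scatter; compounds 1 and 2 differ in several places at once, so their two values are simply recorded side by side and no single change is tied to the gap.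

Compound 3 `CC(C)c1nsc(N2CCC(CCCNc3ccc4c(c3)OCC4=O)CC2)n1` is the next member and differs from compound 2 in one place: 3-isopropyl-1,2,4-thiadiazol-5-yl in place of 5-methoxypyrimidin-2-yl on an amine nitrogen in a ring. The shared core of compounds 2 and 3 and the chain to the ring amine nitrogen are unchanged. Within the data shown here, no measured pair carries this exchange, so the size of the step is not set by any observed step. Since compound 2 already reaches 106% in this assay, the change is expected to give at most a small step, downward if any, not beyond the scatter. Compound 3 is therefore estimated at 100% in this assay, within 78% to 118%, an expected step of a number 6 percentage points lower from compound 2 to compound 3 (within the scatter).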

Compound 3, largest response reached (Emax), in percent of the reference or control that the assay uses: 93%
Beside the measured number, compound 3's estimate is 7 percentage points above it; measured number inside the range.
By their numbers in this assay, from the lowest: compounds 1 and 3 (each within the scatter of the next); then compound 2.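

Among these compounds, the exchange of 5-methoxypyrimidin-2-yl for 3-isopropyl-1,2,4-thiadiazol-5-yl on an amine nitrogen in a ring provides the first single-place comparison: this assay shows a number 13 percentage points lower from compound 2 to compound 3 (beyond the scatter) and thereby establishes that the maximal response can shift with the group at this position, though the step is modest. The two groups have the same counts of heavy atoms, hydrogen-bond donors and hydrogen-bond acceptors and carry no net charge, so these matching counts do not by themselves keep the response unchanged; they differ in ring size, ring hetero atoms and the appended isopropyl and methoxy groups. No measurement in hand identifies what underlies this step.

On these data alone, with a single step, it remains open whether the difference follows the ring or its substituent, a question that 5-isopropylpyrimidin-2-yl or 3-methoxy-1,2,4-thiadiazol-5-yl on the same nitrogen could address. As far as these compounds go, how a tert-butoxycarbonyl group at this nitrogen would read out on the shared core of compounds 2 and 3 also remains open.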